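A few compounds are considered here, and "the series" means these few. Any claim that something is new, unique, unknown or untested is made for them only; others in the source may bear on it.

Measured compounds in a functional assay (Cavia porcellus) with sulfonylurea receptors; K-ATP channels (Homo sapiens) as the target; on this read-out higher numbers stand for weaker inhibition and lower numbers for stronger inhibition:
- compound 1, `CC(O)(C(=O)Nc1ccc(S(=O)(=O)c2cccc(O)c2)cc1)C(F)(F)F`: 18000 nM
- compound 2, `Cc1cccc(S(=O)(=O)c2ccc(NC(=O)C(C)(O)C(F)(F)F)cc2)c1`: 2200 nM
- compound 3, `CC(O)(C(=O)Nc1ccc(S(=O)(=O)c2cccc(C(F)(F)F)c2)cc1)C(F)(F)F`: > 30000 nM

The value of compound 3 is a limit of this assay, not a number (the limit of > 30000 nM in this assay, at which 1 of the 3 values shown sits).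

Compound 2 gives the lowest number of the two that were measured; the nearest is compound 1, reached by an 8.2-fold lower number from compound 1 to compound 2 (0.91 log units; beyond the scatter). From compound 2 to compound 3 the step is an at least 13-fold higher number from compound 2 to compound 3 (1.13 log units; beyond the scatter), and from compound 1 to compound 3 it is an at least 1.6-fold higher number from compound 1 to compound 3 (0.22 log units; that floor lies within the scatter).

Compound 4, `CC(O)(C(=O)Nc1ccc(S(=O)(=O)c2cncs2)cc1)C(F)(F)F`, is not yet measured. It differs from compound 2 by 1,3-thiazol-5-yl in place of 3-methylphenyl on a sulfonyl sulfur. For the measured compounds named here, none of the measured steps exchanges the ring itself; all three vary only a substituent on the same aromatic ring. They show that this part of the shared core is sensitive: hydroxy and trifluoromethyl both give far higher numbers than methyl. A 1,3-thiazol-5-yl ring in place of 3-methylphenyl is a larger change than any of those, so the direction is uncertain, but the step from compound 2 is expected to be toward a higher number, a 4.5-fold higher number from compound 2 to compound 4 (0.66 log units; beyond the scatter).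

For compound 4 the estimate in this assay is 10000 nM, with a range from 2500 nM to 40000 nM.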

Compound 4, half-maximal inhibitory concentration: 7700 nM
Beside the measured number, compound 4's estimate is 1.3-fold (0.11 log units) above it; the measured number falls inside the stated range.
By their numbers in this assay, from the lowest: compound 2; then compound 4; then compound 1. At a limit, above all of these: compound 3.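

Exchange of the whole ring on the sulfonyl sulfur, and not only of a substituent on it, can now be read in this assay: 1,3-thiazol-5-yl in place of 3-methylphenyl gives a 3.5-fold higher number from compound 2 to compound 4 (0.54 log units; beyond the scatter), so this five-membered aromatic ring with 2 hetero atoms does not match the best ring shown. Against 3-hydroxyphenyl the same exchange gives a 2.3-fold lower number from compound 1 to compound 4 (0.37 log units; beyond the scatter), which places 1,3-thiazol-5-yl between the two phenyl rings with measured numbers and shows that a ring without a benzene frame can still give a lower number than one of them. No cause for either step can be drawn, as no property of these rings has been measured here.

Nothing here separates the loss of the methyl from the exchange of the ring itself, and plain phenyl on the sulfonyl sulfur would divide the two effects. Going by these compounds, how an amine in place of the methyl of compound 2, or a methyl added to the 1,3-thiazol-5-yl ring of compound 4, would read remains open.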